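Compound 4: methyl in place of vinyl on the amide carbonyl

The compounds below may be only part of what the source reports. "The series", "measured", "known", "first", "only" and "open" are said of these compounds alone.

Measured in an assay on Sf9 cells for inhibition of mitogen-activated protein kinase kinase kinase 14 variant S549D (Homo sapiens), with a stated time of 30 min, in the presence of a further agent that is not named here; a higher number here means a weaker inhibitor, a lower number a stronger inhibitor:
compound 1 `C#Cc1ccc2ncn(-c3ccnc(N)n3)c2c1`: 251 nM
compound 2 `CCc1ccc2ncn(-c3ccnc(N)n3)c2c1`: 79400 nM
compound 3 `C=CC(=O)NCCCc1ccc2ncn(-c3ccnc(N)n3)c2c1`: 501000 nM

Compound 3 carries the highest number of the three in this assay. The nearest is compound 2, with a 6.3-fold higher number from compound 2 to compound 3 (0.80 log units; beyond the scatter). The gap to compound 1 is wider, a 2000-fold higher number from compound 1 to compound 3 (3.30 log units; beyond the scatter). The remaining measured step, a 320-fold higher number from compound 1 to compound 2 (2.50 log units; beyond the scatter), shows how much the number moves when the ethynyl on the aromatic carbon is exchanged for ethyl.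

Compound 4 `CC(=O)NCCCc1ccc2ncn(-c3ccnc(N)n3)c2c1` differs from compound 3 in one place: methyl in place of vinyl on a carbonyl carbon. Among the measured compounds shown here, none of the measured steps alters the group on the carbonyl carbon; all three concern the substituent on the aromatic carbon. For the measured compounds named here, only the step that introduces the whole amide-bearing chain, a 6.3-fold higher number from compound 2 to compound 3 (0.80 log units; beyond the scatter), touches the amide at all, and it does not separate the vinyl from the rest of that chain. Going by the values given here, there is thus no measured precedent for this change. No step beyond the scatter is expected in this assay, and the expected 1.2-fold higher number from compound 3 to compound 4 (0.08 log units; within the scatter) reflects that. Compound 4 is therefore estimated at 600000 nM, within 200000 nM to 2000000 nM. Compound 3 already reads 501000 nM, the highest number among the measured compounds, so the expectation for compound 4 lies at the weak end of the measured range.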

Compound 4, half-maximal inhibitory concentration: > 100000 nM
Compound 4 was reported as a limit; the forecaster's own chance of this, stated with the estimate: 30%; the middle value lies beyond the limit too.
By their numbers in this assay, from the lowest: compound 1; then compound 2; then compound 3.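

In this assay compound 4 gives > 100000 nM, which is a limit of the assay and not a number: the limit of > 100000 nM in this assay, at which 1 of the 4 values shown sits.

The step between compound 3 and compound 4 cannot be read, so the exchange of vinyl for methyl on the carbonyl carbon has no measurable size here, and the two compounds cannot be placed in order. What is new is that the large loss against the ethynyl compound persists without the vinyl: 3-acetamidopropyl in place of ethynyl on the aromatic carbon gives an at least 390-fold higher number from compound 1 to compound 4 (2.60 log units; beyond the scatter). Against the ethyl compound the reading is weaker evidence, with an at least 1.2-fold higher number from compound 2 to compound 4 (0.10 log units; that floor lies within the scatter), so acetamidomethyl in place of hydrogen on the saturated chain carbon has no established effect.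

On these data alone, it remains open whether any chain on this aromatic carbon can come near compound 1, for example one ending in an amine or a carboxylic acid in place of the amide. Also open, as far as these compounds go, is whether a group close to ethynyl, such as a nitrile or propynyl, would hold the reading of compound 1 at 251 nM.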